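The source may hold more compounds than are shown below. What is called first, only, known or untested is meant among the compounds shown, and "the series" means these compounds.

Measured in a functional assay on MOLT-4 cells (Homo sapiens) for antiproliferative activity; a higher number here means a weaker inhibitor, a lower number a stronger inhibitor:

- compound 1 `COc1ccc(-c2cc(N)c(C(=O)c3cc(OC)c(OC)c(OC)c3)s2)cc1OC` gives 20 nM
- compound 2 `COc1cc(C(=O)c2sc(-c3ccc(Cl)c(Cl)c3)cc2N)cc(OC)c1OC` gives 270 nM
- compound 3 `COc1cc(C(=O)c2sc(-c3ccc(F)cc3)cc2N)cc(OC)c1OC` gives 12 nM

Compound 3 (12 nM) lies within the scatter of compound 1 (20 nM), and the large gaps in the series both involve compound 2: a 14-fold higher number from compound 1 to compound 2 (1.13 log units; beyond the scatter) and a 23-fold lower number from compound 2 to compound 3 (1.35 log units; beyond the scatter).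

Compound 4 `CCOc1ccc(-c2cc(N)c(C(=O)c3cc(OC)c(OC)c(OC)c3)s2)cc1` carries ethoxy in place of fluoro on an aromatic carbon, para to a large group (ethoxy in place of fluoro on an aromatic carbon). For the measured compounds named here, no measured step makes this exact change. The closest evidence is the swap of 3,4-dimethoxyphenyl for 4-fluorophenyl, which stays within the scatter (a 1.7-fold lower number from compound 1 to compound 3 (0.22 log units; within the scatter)). Compound 2 goes against any reading that changes here are generally tolerated (a 23-fold lower number from compound 2 to compound 3 (1.35 log units; beyond the scatter)), so the upper end of the range is kept wide. In this assay, a step within the scatter is expected (a 1.3-fold higher number from compound 3 to compound 4 (0.10 log units; within the scatter)). Compound 4 is estimated at 15 nM (expected range 4 nM to 70 nM).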

Compound 4, half-maximal inhibitory concentration: 240 nM
Estimate against measurement, compound 4: 16-fold (1.20 log units) below, and the stated range ends below it.
By their numbers in this assay, from the lowest: compounds 3 and 1 (each within the scatter of the next); then compounds 4 and 2 (each within the scatter of the next).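

At this position, para to a large group, the change from fluoro to ethoxy is not tolerated in this assay (a 20-fold higher number from compound 3 to compound 4 (1.30 log units; beyond the scatter)), so the small step seen earlier (a 1.7-fold lower number from compound 1 to compound 3 (0.22 log units; within the scatter)) does not extend to every replacement of the ring substituents. An oxygen-linked group here does not by itself keep the number of compound 1, as the 4-ethoxyphenyl ring stands well apart from the 3,4-dimethoxyphenyl ring (a 12-fold higher number from compound 1 to compound 4 (1.08 log units; beyond the scatter)). Compound 2 is also no longer the lone outlier, since the 4-ethoxyphenyl and 3,4-dichlorophenyl rings cannot be told apart (a 1.1-fold lower number from compound 2 to compound 4 (0.05 log units; within the scatter)).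

Nothing at hand bears on the reason for this large step. From the compounds shown here alone, it remains open whether 4-methoxyphenyl, 4-hydroxyphenyl or an amine at this place would group with compound 3 or with compound 4.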